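The compounds below may be only part of what the source reports. "The series", "measured", "known", "first", "only" and "open" are said of these compounds alone.

Compound 1 `O=C(OCC1COCCOCCOCCOCCOCCO1)c1cccc(-c2ccc(Br)cc2)c1` gives 6400 nM in this series.
Compound 2 `CC(C)=CC1C(C(=O)OCC2COCCOCCOCCOCCOCCO2)C1(C)C` gives 40000 nM.

In a functional assay on HBL-100 cells (Homo sapiens) for inhibition, read by sulforhodamine B assay, with a stated time of 48 h (on this read-out lower numbers stand for stronger inhibition of growth and higher numbers for weaker inhibition of growth), compound 2 stands at the higher of the two numbers, the weaker end of what has been measured; compound 1 sits well below it, a gap beyond the usual scatter of the method. Compound 3 `CC/C=C/CC(=O)OCC1COCCOCCOCCOCCOCCO1` has not yet been measured. It keeps the same ester linkage and the same large ring-containing core as compound 2, and differs in one place only: pent-2-en-1-yl in place of 2,2-dimethyl-3-(2-methylprop-1-en-1-yl)cyclopropyl on a carbonyl carbon. Going by the values given here, no measured pair shows this kind of change, so the size of the step can only be guessed. Since the group leaving is itself a plain hydrocarbon, and the group entering is a smaller one of the same kind, a step near zero or a small move toward weaker inhibition is expected, a 1.4-fold higher number from compound 2 to compound 3 (0.14 log units; within the scatter). Because compound 2 already gives 40000 nM, compound 3 is expected to land around 55000 nM, with a likely range of 18000 nM to 160000 nM.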

Compound 3, concentration for 50% growth inhibition: > 100000 nM
Compound 3 gave a limit, no number; the forecaster's own chance of this, stated with the estimate: 30%; at least 1.8-fold (0.25 log units) between middle value and limit.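

In this assay, pent-2-en-1-yl in place of 2,2-dimethyl-3-(2-methylprop-1-en-1-yl)cyclopropyl on a carbonyl carbon gives an at least 2.5-fold higher number from compound 2 to compound 3 (0.39 log units; beyond the scatter), so growth inhibition does respond to the group held here, even when both groups contain only carbon and each has one double bond. Compound 3 reads > 100000 nM, which is a limit of the assay and not a number. The step therefore fixes a direction and a minimum size, while its true size stays unknown: the limit of > 100000 nM in this assay, at which 1 of the 3 values shown sits.

This single change removes the three-membered ring and also leaves fewer carbons, and the compounds shown cannot separate these two differences. Also open, going by these compounds, is how a longer hydrocarbon chain, a saturated pentyl chain or a chain bearing an amine would behave at this position.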